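Swapping Methyl for Fluoro in a Cytotoxicity Series

This account rests on a few compounds, and the source may have more. Where it says the series, first, only, none or still open, it means among the compounds named here.

Compound 1, `Cc1ccc2oc(-c3ccc(NC(=O)CN4CCN(CCN(C)C)CC4)cc3)nc2c1`: 3660 nM
Compound 2, `CN(C)CCN1CCN(CC(=O)Nc2ccc(-c3nc4cc(F)ccc4o3)cc2)CC1`: 16600 nM
Compound 3, `Cc1ccc2oc(-c3ccc(NC(=O)CCl)cc3)nc2c1`: 36100 nM

Of the compounds shown here, three have been measured in a functional assay on A549 cells (Homo sapiens) for cytotoxicity, read by MTT assay, with a stated time of 24 h; a lower number here means a stronger inhibitor, a higher number a weaker inhibitor. Compound 1 and compound 2 share one core and differ only by fluoro in place of methyl on an aromatic carbon. That single swap gave a 4.5-fold higher number from compound 1 to compound 2 (0.66 log units; beyond the scatter) in this assay, a clear weakening. Compound 3 carries a different core; the difference between the core of compound 3 and the core of compound 1 is not broken down here, and compound 3 gives the highest number of the three measured.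

Compound 4, `O=C(CCl)Nc1ccc(-c2nc3cc(F)ccc3o2)cc1`, has not yet been measured. It stands to compound 3 exactly as compound 2 stands to compound 1: the change is fluoro in place of methyl on an aromatic carbon, and the place of the change is the same in both pairs, so this is the same change made a second time on another core. Because the first occurrence produced a 4.5-fold higher number from compound 1 to compound 2 (0.66 log units; beyond the scatter), a step of similar size and direction, a 3.6-fold higher number from compound 3 to compound 4 (0.56 log units; beyond the scatter), is expected from compound 3 to compound 4. On that basis compound 4 is estimated at 130000 nM in this assay, most likely between 45000 nM and 400000 nM, with a real chance that so weak an inhibitor is reported only as a limit.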

Compound 4, half-maximal inhibitory concentration: 37700 nM
The estimate for compound 4 lay 3.4-fold (0.54 log units) above the measured number; measured number below the stated range.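

In this assay the swap of fluoro in place of methyl gave a 1.0-fold higher number from compound 3 to compound 4 (0.02 log units; within the scatter) and so left no readable effect on this second core. The weakening seen with the core of compound 1 therefore did not carry over, and the effect of this swap depends on the core that carries it, as the two steps differ by more than the scatter: the same change on two cores in this assay, a 4.5-fold higher number (0.66 log units; beyond the scatter) from compound 1 to compound 2 and a 1.0-fold higher number (0.02 log units; within the scatter) from compound 3 to compound 4, 4.3-fold (0.64 log units) apart, beyond the scatter of two such steps. This does not show which part of the two cores sets the difference, and two pairs are too few to say how the swap would behave on a third core.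

The compounds shown leave open whether other groups in the same place, such as chloro or methoxy, would also differ between the two cores. They also leave open whether a side chain ending in a simple amine or a carboxylic acid would follow the pattern of compound 2 or that of compound 4.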